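The source may report more compounds than this note shows. Statements on the series, on what has been measured and on what is new or still open speak of the compounds shown alone.

Compound 1 `COc1cc(-c2ccnc3cc(-c4ccc(Cl)cc4)nn23)cc(OC)c1OC`: 3340 nM
Compound 2 `COc1ccc(-c2cc3nccc(-c4cc(OC)c(OC)c(OC)c4)n3n2)cc1F`: 2840 nM

Going by the values given here, in a functional assay on HCT-116 cells (Homo sapiens) for inhibition, read by CCK-8 assay, with a stated time of 48 h (on this read-out higher numbers stand for weaker inhibition and lower numbers for stronger inhibition), compound 2 gives the lowest of the two numbers, but only by a margin within the scatter: the single measured step, a 1.2-fold lower number from compound 1 to compound 2 (0.07 log units; within the scatter), shows how little this kind of exchange moved the read-out. Compound 3 `COc1cc(-c2ccnc3cc(-c4ccc5cnn(C)c5c4)nn23)cc(OC)c1OC` carries a different change: 1-methyl-1H-indazol-6-yl in place of 3-fluoro-4-methoxyphenyl on an aromatic carbon. Among the compounds with values here, no measured step involves this group, so the one comparison at hand gives only weak guidance and suggests no shift beyond the scatter. For compound 3 the expected step is a 1.1-fold lower number from compound 2 to compound 3 (0.04 log units; within the scatter), an estimate of 2600 nM, with a range from 900 nM to 7500 nM.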

Compound 3, half-maximal inhibitory concentration: 2440 nM
For compound 3 the middle estimate is 1.1-fold (0.03 log units) above the measured one; measured number inside the range.
By their numbers in this assay, from the lowest: compounds 3, 2 and 1 (each within the scatter of the next).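

In this assay the aromatic carbon of the shared core now carries 1-methyl-1H-indazol-6-yl, with one five-membered and one six-membered aromatic ring, where the earlier groups had a single six-membered ring. Even so, the read-out stays within the scatter, with a 1.2-fold lower number from compound 2 to compound 3 (0.07 log units; within the scatter) and a 1.4-fold lower number from compound 1 to compound 3 (0.14 log units; within the scatter). The three groups at this position therefore cannot be told apart, and no measured evidence bears on this result. Still open, on these data alone, is whether an amine or a carboxylic acid at this position would give a step beyond the scatter.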